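Adding a second methyl group to compound 3

This account rests on a few compounds, and the source may have more. Where it says the series, first, only, none or still open, it means among the compounds named here.

In a functional assay on HL-60 cells (Homo sapiens) for cytotoxicity, read by WST assay, with a stated time of 48 h (a higher number here means that more compound is needed for the effect, a lower number that less compound is needed), compound 1 `Fc1ccccc1C[C@H]1COC[C@@H]1Cc1ccc(Cl)c(Cl)c1` gives 51000 nM, compound 2 `COc1cccc(C[C@H]2COC[C@@H]2Cc2ccc(Cl)c(Cl)c2)c1` gives 73000 nM and compound 3 `Cc1cccc(C[C@H]2COC[C@@H]2Cc2ccc(Cl)c(Cl)c2)c1` gives 28000 nM. Compound 3 has the lowest of the three numbers, but the margin is small: a 1.8-fold lower number from compound 1 to compound 3 (0.26 log units; within the scatter), and a 2.6-fold lower number from compound 2 to compound 3 (0.42 log units; beyond the scatter).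

Compound 4 `Cc1ccc(C[C@H]2COC[C@@H]2Cc2ccc(Cl)c(Cl)c2)cc1C` differs from compound 3 by methyl in place of hydrogen on an aromatic carbon, ortho to a methyl group and para to a large group. Both measured steps change this side of the molecule and remain small, so no step beyond the scatter is expected in this assay, and no direction is favoured. Compound 4 is expected at 25000 nM, with an estimated range of 11000 nM to 55000 nM. The estimated change is a 1.1-fold lower number from compound 3 to compound 4 (0.05 log units; within the scatter).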

Compound 4, half-maximal effective concentration: 36000 nM
Compound 4: the middle estimate sits 1.4-fold (0.16 log units) below what was measured; low and high end bracket the measured number.
By their numbers in this assay, from the lowest: compounds 3, 4, 1 and 2 (each within the scatter of the next, the first and the last beyond it).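

In this assay, methyl in place of hydrogen on an aromatic carbon, ortho to a methyl group and para to a large group, gives a 1.3-fold higher number from compound 3 to compound 4 (0.11 log units; within the scatter). This position therefore accepts a second small carbon group on the ring without a step beyond the scatter, at least for this one methyl group. No measurement at hand explains this result.

From the compounds shown here alone, whether an amine or a carboxylic acid at this position would give a step beyond the scatter remains open. Going by these compounds, the effect of replacing the methyl group with a longer chain is also open.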